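The source may report more compounds than this note shows. Statements on the series, on what has been measured and on what is new or still open speak of the compounds shown alone.

Compound 1 `Cn1nccc1-c1ccccc1NCC1=NCCN1` was assessed in an in vitro functional assay on cells (Fibroblast) for agonist activity at Alpha-1B adrenergic receptor (Homo sapiens); a lower number here means that less compound is needed, a higher number that more compound is needed for the effect. In this assay compound 1 gives < 100000 nM, which is a limit of the assay and not a number. Compound 2 `CC(C)n1nccc1-c1ccccc1NCC1=NCCN1` carries isopropyl in place of methyl on an aromatic nitrogen, and in this assay compound 2 gives < 100000 nM, again a limit. Compound 3 `CCCn1nccc1-c1ccccc1NCC1=NCCN1` carries propyl in place of isopropyl on an aromatic nitrogen, and in this assay compound 3 gives < 100000 nM, also a limit. The steps among the three are a step that the two limits leave unreadable from compound 1 to compound 2, a step that the two limits leave unreadable from compound 1 to compound 3 and a step that the two limits leave unreadable from compound 2 to compound 3; because of the limit of < 100000 nM in this assay, at which 3 of the 3 values shown sit, none of them can be sized, and compound 1 stands only at a limit with no number of its own.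

Compound 4 `Cn1ccnc1-c1ccccc1NCC1=NCCN1` has not yet been measured in this assay. It differs from compound 1 by 1-methyl-1H-imidazol-2-yl in place of 1-methyl-1H-pyrazol-5-yl on an aromatic carbon. Among the measured compounds shown here, none of the measured steps touches this change; all three vary only the group on the aromatic nitrogen, and none of them can be read. From them no size or direction of step in this assay can be expected beyond the scatter. For compound 4 the estimated value in this assay is 10000 nM, with a range from 500 nM to 100000 nM, and the step that this estimate means is expected to be a step that the limit leaves unreadable from compound 1 to compound 4.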

Compound 4, half-maximal effective concentration: 39.8 nM
Beside the measured number, compound 4's estimate is 250-fold (2.40 log units) above it, outside the stated range (below it).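

The step from compound 1 to compound 4 cannot be sized in this assay, because compound 1 stands only at a limit, not a number: the limit of < 100000 nM in this assay, at which 3 of the 4 values shown sit. The compounds shown leave open how large the effect of 1-methyl-1H-imidazol-2-yl in place of 1-methyl-1H-pyrazol-5-yl is, and whether the group on the aromatic nitrogen matters.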